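The compounds below may be only part of what the source reports. "The series", "measured", "known", "first", "only" and "open" are said of these compounds alone.

Compound 1 `CCCOc1cc(C)c2c(c1C)CC(C(C)C(=O)NCc1cccs1)CC2` is tested in a functional assay for inhibition of Polyunsaturated fatty acid 5-lipoxygenase (Homo sapiens) (on this read-out higher numbers stand for weaker inhibition and lower numbers for stronger inhibition), where compound 1 gives 8000 nM. Among the measured compounds shown here, this is the only plain number among the two results, since the other result is a limit, as noted in the limit of > 10000 nM in this assay, at which 1 of the 2 values shown sits. Compound 2 `COCCOc1cc(C)c2c(c1C)CC(C(C)C(=O)NC1CCCC1)CC2` reaches only the limit of > 10000 nM in this assay. Compound 3 `CCCOc1cc(C)c2c(c1C)CC(C(C)C(=O)Nc1ccccn1)CC2` differs from compound 1 by pyridin-2-yl in place of (thiophen-2-yl)methyl on an amide-type nitrogen. No measured step of this kind exists among these compounds, so the expected step from compound 1 to compound 3 in this assay is estimated at a 1.5-fold higher number from compound 1 to compound 3 (0.18 log units; within the scatter), a small weakening close to the scatter. Compound 3 is therefore expected to give about 12000 nM, between 4000 nM and 40000 nM.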

Compound 3, half-maximal inhibitory concentration: 900 nM
Compound 3: middle estimate off by 13-fold (1.12 log units), on the high side; the whole stated range lies above it.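

Among the compounds shown here, the first comparison here in which only one place differs puts pyridin-2-yl in place of (thiophen-2-yl)methyl on an amide-type nitrogen, and in this assay it gives an 8.9-fold lower number from compound 1 to compound 3 (0.95 log units; beyond the scatter). The group on this nitrogen therefore affects inhibition, even though both groups have the same heavy-atom count and one aromatic ring each. Nothing given here explains the stronger inhibition. Going by these compounds, it remains open whether the change comes from the ring itself or from losing the carbon link to the nitrogen, a question that phenyl or (pyridin-2-yl)methyl on the same nitrogen would help separate.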